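A few compounds are considered here, and "the series" means these few. Any claim that something is new, unique, unknown or untested is made for them only; others in the source may bear on it.

Measured compounds:
- compound 1, `O=P(O)(O)Oc1cc(OP(=O)(O)O)c(OP(=O)(O)O)c(OP(=O)(O)O)c1`: 78000 nM
- compound 2, `O=P(O)(O)Oc1ccc(OP(=O)(O)O)c(OP(=O)(O)O)c1OP(=O)(O)O`: 98000 nM

Of the compounds shown here, two have so far been measured in an assay for inhibition of inositol polyphosphate-5-phosphatase A (Homo sapiens), read by malachite green, with a stated time of 10 min; a lower number here means a stronger inhibitor, a higher number a weaker inhibitor. Compound 1 gives 78000 nM there, and compound 2 gives 98000 nM. For the measured compounds named here, the two numbers lie within the scatter of each other, so compound 2 stands level with compound 1 rather than apart from it; both are weak inhibitors on this scale, and there is no step between them from which the weight of any single group could be read.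

Compound 3, `O=P(O)(O)Oc1ccc(OP(=O)(O)O)c(OP(=O)(O)O)c1`, is the next compound to be measured in this assay. It differs from compound 2 by a hydrogen atom in place of a group of 5 heavy atoms (4 oxygen, 1 phosphorus; no ring), on an aromatic carbon. Going by the values given here, no measured pair shows what removing such a group does, so the expectation rests only on the shared core of compound 2 and the loss of one of its four groups. The loss of one of four like groups is expected to weaken inhibition, giving a higher number in this assay, by a step somewhat beyond the scatter rather than by a large margin; an outcome within the scatter cannot be excluded. Compound 3 is therefore expected to give about 220000 nM, within a range from 90000 nM to 600000 nM. Expressed as a step, the estimate means a 2.2-fold higher number from compound 2 to compound 3 (0.35 log units; beyond the scatter).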

Compound 3, half-maximal inhibitory concentration: 14000 nM
Estimate against measurement, compound 3: 16-fold (1.20 log units) above; the whole stated range lies above it.
By their numbers in this assay, from the lowest: compound 3; then compounds 1 and 2 (each within the scatter of the next).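

In this assay, taking the group of 5 heavy atoms (4 oxygen, 1 phosphorus; no ring) off the aromatic carbon, ortho to two groups of 5 heavy atoms each and meta to a group of 5 heavy atoms, does not cost inhibition: the change gives a 7.0-fold lower number from compound 2 to compound 3 (0.85 log units; beyond the scatter) and so makes a stronger inhibitor. Read against the other compound that carries one such group more, the result points the same way, with a 5.6-fold lower number from compound 1 to compound 3 (0.75 log units; beyond the scatter), so both available steps show that this group is not needed for inhibition here and that compound 3, with one such group fewer, stands clearly apart from the level pair of compound 1 and compound 2. Nothing available explains why the loss of the group goes with stronger inhibition.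

The compounds shown leave open whether a hydroxyl, a methyl or a carboxylic acid in place of the hydrogen at this carbon would keep the gain. They also leave open whether losing any of the remaining groups of 5 heavy atoms from compound 3 would strengthen inhibition further or weaken it.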